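This account rests on a few compounds, and the source may have more. Where it says the series, first, only, none or still open, it means among the compounds named here.

Measured compounds:
compound 1, `Cc1ccccc1-n1nc(C)c2c1NC(=O)[C@H](C)S[C@@H]2c1ccc(-c2ccoc2)cc1`, in an assay on isolated protein for agonist activity at Bile acid receptor (Homo sapiens), read by AlphaScreen, with a stated time of 30 min (on this read-out higher numbers stand for an effect only at larger amounts of compound and lower numbers for an effect already at smaller amounts), compound 1 gives 3500 nM.
compound 2, `Cc1ccccc1-n1nc(C)c2c1NC(=O)[C@H](C)S[C@@H]2c1ccc(-c2ccccc2)cc1`, in this assay compound 2 gives 990 nM.

Compound 2 has the lowest number of the two; its nearest neighbour is compound 1, and the step of a 3.5-fold lower number from compound 1 to compound 2 (0.55 log units; beyond the scatter) lies beyond the scatter.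

Compound 3, `COc1ccccc1Oc1ccc([C@H]2S[C@@H](C)C(=O)Nc3c2c(C)nn3-c2ccccc2C)cc1`, differs from compound 2 in one place: 2-methoxyphenoxy in place of phenyl on an aromatic carbon. For the measured compounds named here, the only measured step that bears on this position is a 3.5-fold lower number from compound 1 to compound 2 (0.55 log units; beyond the scatter), a modest change when one aromatic ring was exchanged for another at the same place. Going by the values given here, the new group is larger and carries two hydrogen-bond acceptors, and no measured pair shows such an exchange, so the direction is uncertain. The account therefore expects for compound 3 a step of about a 1.5-fold higher number from compound 2 to compound 3 (0.18 log units; within the scatter), which may fall either side of the scatter. The estimate for compound 3 in this assay is 1500 nM, within a range from 400 nM to 6000 nM.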

Compound 3, half-maximal effective concentration: 1700 nM
Estimate against measurement, compound 3: 1.1-fold (0.05 log units) below, within the range that was stated.
By their numbers in this assay, from the lowest: compounds 2 and 3 (each within the scatter of the next); then compound 1.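

In this assay, the step of a 1.7-fold higher number from compound 2 to compound 3 (0.23 log units; within the scatter) shows that this aromatic carbon, para to a large group, accepts 2-methoxyphenoxy, a group with more heavy atoms than phenyl and with hydrogen-bond acceptors, with no change that can be told from the scatter. The step of a 2.1-fold lower number from compound 1 to compound 3 (0.31 log units; beyond the scatter) adds a second group that reads lower than furan-3-yl at this place, though the change is modest and compound 2 with phenyl gives the same picture. Nothing available explains why these groups read as they do.

The compounds shown do not separate the contribution of the ring oxygen linking the new aromatic ring from that of its methoxy group, as plain phenoxy or 2-methoxyphenyl would. They also leave open how an amine or a carboxylic acid would read on this aromatic carbon.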